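Working notes: propoxy to ((tert-butyl)carbonyl)oxy

A few compounds are considered here, and "the series" means these few. Any claim that something is new, unique, unknown or untested is made for them only; others in the source may bear on it.

- compound 1 `CCOc1ccc2oc(/C=C/[S+](C)[O-])cc(=O)c2c1`: 4900 nM
- compound 2 `CCCOc1ccc2oc(/C=C/[S+](C)[O-])cc(=O)c2c1`: 6200 nM

Both values come from a functional assay on DLD-1 cells (Homo sapiens) for cytotoxicity, with a stated time of 48 h; a lower number here means a stronger inhibitor, a higher number a weaker inhibitor. For the measured compounds named here, with only two measured compounds, compound 2 at 6200 nM stands within the scatter of compound 1 at 4900 nM. The next compound to consider is compound 3 `C[S+]([O-])/C=C/c1cc(=O)c2cc(OC(=O)C(C)(C)C)ccc2o1`, which differs from compound 2 as follows: (tert-butyl)carbonyl in place of propyl on an oxygen on an aromatic ring. This places (tert-butyl)carbonyl in place of propyl on an oxygen on an aromatic ring, so propoxy becomes ((tert-butyl)carbonyl)oxy.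

Going by the values given here, only one measured step bears on this change: a 1.3-fold higher number from compound 1 to compound 2 (0.10 log units; within the scatter). That step extends a saturated chain and brings in no carbonyl, so it is weak guidance. Among the compounds with values here, no measured compound carries a carbonyl on this oxygen, and the data give no direction for the change. The working expectation in this assay is therefore no shift beyond the scatter, with a wide margin on either side. The expected step is a 1.1-fold lower number from compound 2 to compound 3 (0.05 log units; within the scatter). For compound 3 the estimated value is 5500 nM, with an expected range of 1800 nM to 17000 nM.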

Compound 3, half-maximal inhibitory concentration: 8000 nM
The estimate for compound 3 lay 1.5-fold (0.16 log units) below the measured number, and the stated range covers the measured number.
By their numbers in this assay, from the lowest: compounds 1, 2 and 3 (each within the scatter of the next).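

In this assay, (tert-butyl)carbonyl in place of propyl on the oxygen on an aromatic ring gives a 1.3-fold higher number from compound 2 to compound 3 (0.11 log units; within the scatter), and the same group in place of ethyl gives a 1.6-fold higher number from compound 1 to compound 3 (0.21 log units; within the scatter). Until now this position had been explored only with the two saturated chains, ethyl and propyl; the series now shows that an entering group with 6 heavy atoms, a double bond outside aromatic rings and a hydrogen-bond acceptor leaves the number within the scatter of both. No measurement is available that would explain this result or tie it to any property of the group.

The compounds shown do not separate the contribution of the carbonyl from that of the branched tert-butyl, so an acetyl on the same oxygen or a neopentyl chain would be needed to read them apart. Also open, as far as these compounds go, is whether a free hydroxyl, a longer chain such as octyl, or a chain ending in an amine or a carboxylic acid would move the number beyond the scatter.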